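One Chloro Fewer on a Shared Fused Core

The source may report more compounds than this note shows. Statements on the series, on what has been measured and on what is new or still open speak of the compounds shown alone.

Three compounds have so far been examined in a functional assay on U-251 cells (Homo sapiens) for cytotoxicity, read by sulforhodamine B assay, with a stated time of 48 h; a lower number here means that less compound is tolerated, a higher number that more compound is tolerated. Compound 1 `ClCc1cccc(Cn2cnc3c(Cl)ncnc32)c1` gives 6760 nM in this assay. Compound 2 `ClCc1ccc(Cn2cnc3nc(Cl)nc(Cl)c32)cc1` gives 5750 nM in this assay, and compound 3 `ClCc1cccc(Cn2cnc3c(Cl)nc(Cl)nc32)c1` gives 5620 nM. All three numbers lie within the usual scatter of one another, so no order among them can be claimed.

Compound 3 and compound 1 differ in one place: hydrogen in place of chloro on an aromatic carbon. The step of a 1.2-fold higher number from compound 3 to compound 1 (0.08 log units; within the scatter) shows that this change did not move the number beyond the scatter. Compound 2 and compound 3 are built from the same atoms joined differently; the difference between the two cores is not broken down here.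

Compound 4 `ClCc1ccc(Cn2cnc3ncnc(Cl)c32)cc1` has not yet been measured. It stands to compound 2 as compound 1 stands to compound 3: hydrogen in place of chloro on an aromatic carbon. Both place descriptions agree word for word, so this is the same change, applied on a differently joined core. Because the measured step of a 1.2-fold higher number from compound 3 to compound 1 (0.08 log units; within the scatter) is within the scatter, the same change made on compound 2 is expected to behave alike, and compound 4 is estimated to show a 1.2-fold higher number from compound 2 to compound 4 (0.08 log units; within the scatter) in this assay. Compound 4 is therefore expected at 6900 nM in this assay, with a plausible range from 3500 nM to 13500 nM.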

Compound 4, concentration lethal to 50% of the cells: 4780 nM
Compound 4: the middle estimate sits 1.4-fold (0.16 log units) above what was measured, within the range that was stated.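

In this assay, the new step, a 1.2-fold lower number from compound 2 to compound 4 (0.08 log units; within the scatter), lies within the scatter, so hydrogen in place of chloro on an aromatic carbon leaves the number on this second core as indistinguishable as it was on the first. Set beside the earlier step, the new one does not stand apart, and on these two cores the change can be carried across without a detectable difference: the same change on two cores in this assay, a 1.2-fold higher number (0.08 log units; within the scatter) from compound 3 to compound 1 and a 1.2-fold lower number (0.08 log units; within the scatter) from compound 2 to compound 4, 1.4-fold (0.16 log units) apart, within the scatter of two such steps This shows only that a change with no readable effect on one core also has no readable effect on the other; the opposite directions of the two printed steps cannot be taken as a difference between the cores, and two pairs within the scatter say nothing about whether a change that moved the number beyond the scatter would carry across in the same way.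

The compounds shown leave open whether an amine or a methoxy group, rather than hydrogen or chloro, at this place on the six-membered aromatic ring would shift the number beyond the scatter. They also leave open whether a hydroxymethyl group in place of the chloromethyl group would do so on either core.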